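Three Compounds at the Limit and a Fourth Untested

The source may report more compounds than this note shows. Statements on the series, on what has been measured and on what is new or still open speak of the compounds shown alone.

Compound 1 `CS(=O)(=O)c1ccc(C(=O)NCCC(=O)N2CCc3ccccc32)cc1[N+](=O)[O-]` gave > 60000 nM.
Compound 2 `Cc1ccc(N2CCN(C(=O)C3CCN(C(=O)c4ccc(S(C)(=O)=O)c([N+](=O)[O-])c4)CC3)CC2)cc1` gave > 60000 nM.
Compound 3 `CCCN(C(=O)CN(C)C(=O)c1ccc(S(C)(=O)=O)c([N+](=O)[O-])c1)c1ccccc1` gave > 60000 nM.

Each of these three values is a limit of an assay on isolated protein for inhibition of vitamin D3 receptor (Homo sapiens), read by fluorescence polarization (a higher number here means a weaker inhibitor, a lower number a stronger inhibitor), rather than a number. Within the data shown here, compound 3 therefore stands where the other two stand: all three sit at the limit of > 60000 nM in this assay, at which 3 of the 3 values shown sit, and no measured step separates any pair of them. Compound 4 `CN(Cc1cccc(F)c1)C(=O)CN(C)C(=O)c1ccc(S(C)(=O)=O)c([N+](=O)[O-])c1` differs from compound 3 in one place: (3-fluorobenzyl)(methyl)amino in place of phenyl(propyl)amino on a carbonyl carbon. Among the measured compounds shown here, no measured step exists for a change of this kind here, so the expected step for compound 4 in this assay, a step that the limit leaves unreadable from compound 3 to compound 4, is set at none beyond the scatter. Compound 4 is accordingly expected to give about 80000 nM, within a range from 20000 nM to 300000 nM, most likely again as a limit.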

Compound 4, half-maximal inhibitory concentration: > 60000 nM
Compound 4 was reported as a limit; the forecaster's own chance of this, stated with the estimate: 85%; the middle value lies beyond the limit too.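

Compound 3 and compound 4 both stand at a limit in this assay, so no step can be read between them: the limit of > 60000 nM in this assay, at which 4 of the 4 values shown sit.

The compounds shown leave open how strong an inhibitor any of them is, and whether (3-fluorobenzyl)(methyl)amino in place of phenyl(propyl)amino changes anything.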